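Methylsulfonyl on the ring amine of compound 1

A few compounds are considered here, and "the series" means these few. Any claim that something is new, unique, unknown or untested is made for them only; others in the source may bear on it.

Compound 1 `CCCCNc1nc(N)nc2c1CNCC2` stands with the highest of the three numbers in an assay on HEK293 cells for agonist activity at Toll-like receptor 8 (Homo sapiens), read by a luciferase reporter, with a stated time of 6 h (on this read-out lower numbers stand for an effect already at smaller amounts and higher numbers for an effect only at larger amounts of compound), at 7.2 uM. Compound 2 `CCCCNc1nc(N)nc2c1CCNC2` gives 0.6 uM in this assay, and compound 3 `CCCCNc1nc(N)nc2c1CCN(C)C2` gives 0.2 uM. Within the data shown here, the one measured step at a ring amine nitrogen is a 3.0-fold lower number from compound 2 to compound 3 (0.48 log units; beyond the scatter). Compound 4 `CCCCNc1nc(N)nc2c1CN(S(C)(=O)=O)CC2` has no number yet; it differs from compound 1 by methylsulfonyl in place of hydrogen on an amine nitrogen in a ring. The measured step bears on the same kind of position but introduces a methyl, not a methylsulfonyl, and it was taken on a different core arrangement, so it gives only a loose guide. With nothing closer to lean on, the expectation is a step near the scatter, in either direction, for compound 4; its expected step is a 1.4-fold higher number from compound 1 to compound 4 (0.14 log units; within the scatter). Compound 4 is therefore estimated in this assay at 10 uM, with a range from 2 uM to 40 uM, and a real chance that only a limit is recorded.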

Compound 4, minimum effective concentration: 9.9 uM
Estimate against measurement, compound 4: 1.0-fold (0.00 log units) above, and the stated range covers the measured number.
By their numbers in this assay, from the lowest: compound 3; then compound 2; then compounds 1 and 4 (each within the scatter of the next).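

On this amine nitrogen in a ring, the step of a 1.4-fold higher number from compound 1 to compound 4 (0.14 log units; within the scatter) shows that in this assay hydrogen can give way to methylsulfonyl, a group with no hydrogen-bond donors, while the two numbers stay within the scatter of each other. Among these compounds, the only earlier step at a ring amine nitrogen, a 3.0-fold lower number from compound 2 to compound 3 (0.48 log units; beyond the scatter), concerns methyl on a different core arrangement, so this is the first reading at this position in the core of compound 1. No measurement available here bears on the reason for this result.

Open, from the compounds shown here alone, is whether an acetyl or benzyl group on the same nitrogen would also leave the number of compound 1 within the scatter. Also open, going by these compounds, is whether methylsulfonyl on the ring amine nitrogen of compound 2 would give a step of similar size.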